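The compounds below may be only part of what the source reports. "The series", "measured", "known", "first", "only" and "open" are said of these compounds alone.

Measured in a functional assay on the whole organism with Rattus norvegicus as the target; a lower number here means that less compound is needed, a higher number that more compound is needed for the effect:
- compound 1 `CC(C)(C)Cc1ccc2nc(N)sc2c1`, a limit of the assay: > 10 mg/kg
- compound 2 `Nc1nc2cccc(OC(F)(F)F)c2s1`, a limit of the assay: > 10 mg/kg
- compound 3 `N=c1sc2cc(OC(F)(F)F)ccc2n1Cc1ccccc1`, a limit of the assay: > 10 mg/kg

Among the compounds with values here, no two measured compounds differ in one place, so no step has been measured. Compound 3 stands where all three measured values stand, at the limit of > 10 mg/kg in this assay, at which 3 of the 3 values shown sit, and gives no number of its own. Compound 4 `CSCCn1c(=N)sc2cc(OC(F)(F)F)ccc21` is the next member; it differs from compound 3 by (methylsulfanyl)methyl in place of phenyl on a saturated chain carbon bound to an aromatic nitrogen. With nothing but limits to rest on, the step that the limit leaves unreadable from compound 3 to compound 4 in this assay is expected to be none beyond the scatter, and most probably a further limit. Compound 4 is expected at 15 mg/kg, between 5 mg/kg and 50 mg/kg.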

Compound 4, dose for half-maximal effect: 1 mg/kg
Beside the measured number, compound 4's estimate is 15-fold (1.18 log units) above it, outside the stated range (below it).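

In this assay, (methylsulfanyl)methyl in place of phenyl on a saturated chain carbon bound to an aromatic nitrogen gives an at least 10-fold lower number from compound 3 to compound 4 (1.00 log units; beyond the scatter). The substituent at this place therefore decides whether the series gives a measurable dose, and a group with no ring serves there better than the benzyl of compound 3. Compound 4 is the only one shown with a number rather than a limit: the limit of > 10 mg/kg in this assay, at which 3 of the 4 values shown sit.

Going by these compounds, whether the sulfur itself matters stays open, as a 2-methoxyethyl group or a plain butyl chain at this place would tell. On these data alone, the full size of the step also stays open, as the value of compound 3 is a limit.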